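The compounds below may be only part of what the source reports. "The series", "measured", "known", "first", "only" and "open" are said of these compounds alone.

Measured so far in a functional assay on SH-SY5Y cells (Homo sapiens) for cytotoxicity, read by MTT assay, with a stated time of 48 h; a higher number here means a weaker inhibitor, a lower number a stronger inhibitor:
compound 1, `COc1cc(/C=C/C(=O)/C=C/c2nc3ccccc3n2C)ccc1O`, with 4700 nM;
compound 2, `COc1cc(/C=C/C(=O)/C=C/c2nc3c(C)cccc3n2C)ccc1O`, with 1000 nM;
compound 3, `COc1ccc(/C=C/C(=O)/C=C/c2nc3ccccc3n2C)cc1O`, with 4800 nM.

Compound 1 and compound 3 are built from the same atoms joined differently; the difference between the two cores is not broken down here. In this assay their two numbers lie within the scatter of each other, so nothing separates them. For the measured compounds named here, the one counted change is from compound 1 to compound 2: methyl in place of hydrogen on an aromatic carbon. In this assay it gave a 4.7-fold lower number from compound 1 to compound 2 (0.67 log units; beyond the scatter).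

Compound 4, `COc1ccc(/C=C/C(=O)/C=C/c2nc3c(C)cccc3n2C)cc1O`, is not yet measured. Going by the values given here, it arises from compound 3 by methyl in place of hydrogen on an aromatic carbon, the same change at the same place as the one made on compound 1. Among the compounds with values here, the only precedent for it is a 4.7-fold lower number from compound 1 to compound 2 (0.67 log units; beyond the scatter), and the estimate for compound 4 rests on that alone, starting from compound 3 at 4800 nM. The expected step is therefore a 4.4-fold lower number from compound 3 to compound 4 (0.64 log units; beyond the scatter), of a size close to the earlier one. Compound 4 is expected to give about 1100 nM in this assay, estimated between 500 nM and 2600 nM, the range kept wide because a single precedent is all there is.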

Compound 4, half-maximal inhibitory concentration: 19100 nM
Beside the measured number, compound 4's estimate is 17-fold (1.24 log units) below it; measured number outside the range, above it.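

In this assay, methyl in place of hydrogen on an aromatic carbon gave a 4.0-fold higher number from compound 3 to compound 4 (0.60 log units; beyond the scatter), a step in the opposite direction to the one seen earlier on the other core. The change therefore does not carry from one core to the other in this series, and its effect on one core gave no reliable guide to its effect on the other: the same change on two cores in this assay, a 4.7-fold lower number (0.67 log units; beyond the scatter) from compound 1 to compound 2 and a 4.0-fold higher number (0.60 log units; beyond the scatter) from compound 3 to compound 4, 19-fold (1.27 log units) apart, beyond the scatter of two such steps. These two steps show that the outcome depends on the core, but they do not show which difference between the two cores decides its direction, and two pairs are too few to support a general rule.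

The compounds shown leave open what other groups would do at the same place on each core, for instance fluorine, an amine or a longer chain in place of the methyl. Also open, from the compounds shown here alone, is whether the methyl step on any further core would follow one of these two directions.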